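The compounds below may be only part of what the source reports. "The series", "measured", "known", "first", "only" and "open" are said of these compounds alone.

In a functional assay on HeLa cells (Homo sapiens) for inhibition, read by MTT assay, with a stated time of 48 h (on this read-out higher numbers stand for weaker inhibition and lower numbers for stronger inhibition), three compounds sharing one core have been measured. Compound 1 (`CCOC(=O)C1=C(N/N=C(\C#N)C(N)=O)Nc2[nH]nc(C)c2C1c1ccc(N(C)C)cc1`) gives 47300 nM, compound 2 (`CCOC(=O)C1=C(NN=C(C#N)C#N)Nc2[nH]nc(C)c2C1c1ccc(N(C)C)cc1`) gives 15200 nM, and compound 3 (`CCOC(=O)C1=C(N)Nc2[nH]nc(C)c2C1c1ccc(N(C)C)cc1`) gives 6220 nM, the lowest number of the three. Compound 4 (`CCOC(=O)C1=C(N/C=N/c2ccc([N+](=O)[O-])cc2)Nc2[nH]nc(C)c2C1c1ccc(N(C)C)cc1`) differs from compound 3 by a group of 11 heavy atoms (7 carbon, 2 nitrogen, 2 oxygen; one six-membered aromatic ring of carbon only) in place of a hydrogen atom, on an amine nitrogen. Within the data shown here, two measured steps bear on this change, each replacing a group on that amine nitrogen with hydrogen: a 7.6-fold lower number from compound 1 to compound 3 (0.88 log units; beyond the scatter) and a 2.4-fold lower number from compound 2 to compound 3 (0.39 log units; beyond the scatter), both modest. Neither departing group contains an aromatic ring, so the comparison is loose. Read in reverse, these steps lead to the expectation of a modest rise in this assay. The estimated step is a 2.3-fold higher number from compound 3 to compound 4 (0.35 log units; beyond the scatter). For compound 4 the estimate is 14000 nM, with an expected range of 4000 nM to 50000 nM.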

Compound 4, half-maximal inhibitory concentration: 57800 nM
The estimate for compound 4 lay 4.1-fold (0.62 log units) below the measured number; measured number above the stated range.
By their numbers in this assay, from the lowest: compound 3; then compound 2; then compounds 1 and 4 (each within the scatter of the next).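

Hydrogen on the amine nitrogen remains the lowest point in the series: the group with the six-membered aromatic ring gives a 9.3-fold higher number from compound 3 to compound 4 (0.97 log units; beyond the scatter) and a 3.8-fold higher number from compound 2 to compound 4 (0.58 log units; beyond the scatter) when it replaces the group of 6 heavy atoms. Replacing the group of 7 heavy atoms gives only a 1.2-fold higher number from compound 1 to compound 4 (0.09 log units; within the scatter) and so sets no new level at this position, despite the added ring. No measurement here accounts for these steps.

As far as these compounds go, whether a methyl or acetyl group on this nitrogen would stay close to the free amine remains open. So does whether an amino group or a carboxylic acid in place of the nitro group would shift the number.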